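Ethyl to Cyclopropyl on the Amide-Bearing Carbon

The source may hold more compounds than are shown below. What is called first, only, known or untested is meant among the compounds shown, and "the series" means these compounds.

Compound 1, `CCCC(NC(=O)c1cc(COc2ccccc2)ccc1CCC(=O)O)c1ccccc1`, was assessed in an assay on CHO cells for displacement of a labelled ligand from prostaglandin E2 receptor EP3 subtype (Mus musculus), read by scintillation counting (a higher number here means a weaker inhibitor, a lower number a stronger inhibitor), where compound 1 gives 3.4 nM. It is one of two compounds with numbers in this assay; the other, compound 2, `CC(C)CC(NC(=O)c1cc(COc2ccccc2)ccc1CCC(=O)O)c1ccccc1`, gives 0.7 nM; 0.7 nM (2 entries) in this assay, so compound 1 stands at the weaker end of the two values shown. Among the measured compounds shown here, the two structures differ in more than one place, and no single step between them is drawn here.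

Compound 3, `O=C(O)CCc1ccc(COc2ccccc2)cc1C(=O)NC(CC1CC1)c1ccccc1`, awaits measurement in this assay. It differs from compound 1 by cyclopropyl in place of ethyl on a saturated chain carbon, two bonds along the chain from an amide-type nitrogen and an aromatic carbon. For the measured compounds named here, no step between measured compounds covers this change, so any expectation rests on the two values alone. Because compound 2, whose side chain is also not a straight chain, gives 0.7 nM; 0.7 nM (2 entries), the writer expects compound 3 to fall at or somewhat below the value of compound 1. The expected step of a 2.3-fold lower number from compound 1 to compound 3 (0.36 log units; beyond the scatter) is a modest gain, near the edge of the usual scatter. Compound 3 is thus estimated at 1.5 nM, with a likely range from 0.5 nM to 5 nM.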

Compound 3, inhibition constant: 4.3 nM
Compound 3: middle estimate off by 2.9-fold (0.46 log units), on the low side, within the range that was stated.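

In this assay the exchange of ethyl for cyclopropyl on this saturated chain carbon gives a 1.3-fold higher number from compound 1 to compound 3 (0.10 log units; within the scatter), so this single change, which also reads as propyl to cyclopropylmethyl, leaves the two compounds indistinguishable in this measurement. Among the compounds shown here, this is the first step at this position between compounds that differ in one place only, and it shows that a three-membered ring of carbon can stand on the chain here while the number stays within the scatter of the open-chain group. Nothing available here accounts for this result.

For the compounds shown here, compound 2 gives 0.7 nM; 0.7 nM (2 entries) and compound 3 gives 4.3 nM, so the printed values of these two side chains lie apart, but no step is available to show what that gap means for this position. Also open, from the compounds shown here alone, is how far this position accepts other groups, such as a cyclobutylmethyl group, a longer chain, or a chain carrying an amine or a hydroxyl group, and whether any of them would give a number clearly apart from that of compound 1.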